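Swapping methyl for cyano on selenium in compound 2

The source may hold more compounds than are shown below. What is called first, only, known or untested is meant among the compounds shown, and "the series" means these compounds.

Measured in a functional assay on MDA-MB-231 cells (Homo sapiens) for inhibition, read by MTT assay, with a stated time of 48 h; a higher number here means a weaker inhibitor, a lower number a stronger inhibitor:
- compound 1 `Cc1nc(N(C)c2ccc([Se]C#N)c(C)c2)c2ccccc2n1`: 16 nM
- compound 2 `COc1ccc(N(C)c2nc(C)nc3ccccc23)cc1[Se]C`: 10 nM
- compound 3 `Cc1nc(N(C)c2ccc(OCC[Se]C#N)cc2)c2ccccc2n1`: 317 nM

Compound 2 and compound 1 lie within the scatter of each other, at the low end of these numbers. Compound 3 stands beyond the scatter from compound 2.

Compound 4 `COc1ccc(N(C)c2nc(C)nc3ccccc23)cc1[Se]C#N` has cyano in place of methyl on a selenium. Within the data shown here, no measured pair shows this change alone. Compound 1 carries cyano on a selenium and gives 16 nM, which suggests the group can fit a low number. Compound 3 also carries it, however, and gives 317 nM, so the evidence is mixed.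

In this assay the expected step is a 1.2-fold higher number from compound 2 to compound 4 (0.08 log units; within the scatter), nothing beyond the scatter and with no firm direction. For compound 4 the estimated value is 12 nM, with an expected range of 3 nM to 50 nM.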

Compound 4, half-maximal inhibitory concentration: 52 nM
Estimate against measurement, compound 4: 4.3-fold (0.64 log units) below; the whole stated range lies below it.
By their numbers in this assay, from the lowest: compounds 2 and 1 (each within the scatter of the next); then compound 4; then compound 3.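

Putting cyano in place of methyl on a selenium whose other neighbour is an aromatic carbon gives a 5.2-fold higher number from compound 2 to compound 4 (0.72 log units; beyond the scatter) in this assay. Among these compounds, this is the first direct reading of the change alone, and it shows that the swap is not neutral at this position: methyl holds the lower number. Nothing measured here explains the step.

Still open, going by these compounds, is how a longer chain such as ethyl or propyl on this selenium would compare with methyl and cyano. Whether an amine or a carboxylic acid at the end of such a chain would be tolerated also stays unanswered.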